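Swapping a hydroxyoctyl carbonate tail for a tert-butyl ester

The source may hold more compounds than are shown below. What is called first, only, known or untested is meant among the compounds shown, and "the series" means these compounds.

Measured compounds:
compound 1 `Cc1cn(C2CC(N=[N+]=[N-])C(COC(=O)OCCCCCCCCO)O2)c(=O)[nH]c1=O` — in a functional assay on MT4 cells (Homo sapiens) for cytotoxicity (a higher number here means that more compound is tolerated, a lower number that less compound is tolerated), compound 1 gives > 50000 nM, a limit of the assay.
compound 2 `Cc1cn(C2CC(N=[N+]=[N-])C(COC(=O)NCCCO)O2)c(=O)[nH]c1=O` — in this assay compound 2 gives > 50000 nM, also a limit.

Compound 1 stands at the limit, where both values shown sit (the limit of > 50000 nM in this assay, at which 2 of the 2 values shown sit). Among the measured compounds shown here, the single measured step, a step that the two limits leave unreadable from compound 1 to compound 2, runs between two limits and cannot be sized. Compound 3 `Cc1cn(C2CC(N=[N+]=[N-])C(COC(=O)OCCCC(=O)OC(C)(C)C)O2)c(=O)[nH]c1=O` carries tert-butoxycarbonyl in place of 5-hydroxypentyl on a saturated chain carbon, three bonds along the chain from an oxygen next to a carbonyl group. For the measured compounds named here, no measured step bears on this change, and the values of compound 1 and compound 2 show only that neither gave a number within the range of the assay. Compound 3 is therefore expected to remain at the limit, a step of a number no higher from compound 1 to compound 3 (the limit leaves the size open), with an estimate of 50000 nM (range 25000 nM to 100000 nM).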

Compound 3, half-maximal cytotoxic concentration: > 50000 nM
Compound 3 gave a limit, no number (the forecaster's own chance of this, stated with the estimate: 80%); the middle value lies on the limit itself.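

Among the compounds shown here, compound 3, like compound 1, gives only a limit and not a number, so no step between compound 1 and compound 3 can be read: the limit of > 50000 nM in this assay, at which 3 of the 3 values shown sit. The compounds shown leave open what change to the tail, if any, would give a number within the range of this assay.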